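The source may report more compounds than this note shows. Statements on the series, on what has been measured and on what is new or still open speak of the compounds shown alone.

Of the compounds shown here, three that share one core have been tested in an assay on Prostate gland for inhibition of steroid 5-alpha-reductase (Rattus norvegicus); a lower number here means a stronger inhibitor, a higher number a weaker inhibitor. Compound 3 `C/C(=C\C(=O)Nc1ccccc1OCCCC(=O)O)c1ccc2c(ccn2Cc2ccc(C)cc2)c1` gives 88 nM, the second highest of the three numbers. Compound 1 `CC(C)=CCn1ccc2cc(/C(C)=C/C(=O)Nc3ccccc3OCCCC(=O)O)ccc21` gives 120 nM, while compound 2 `CCCC(CC)n1ccc2cc(/C(C)=C/C(=O)Nc3ccccc3OCCCC(=O)O)ccc21` gives 9.3 nM. Compound 4 `CCC(c1ccccc1)n1ccc2cc(/C(C)=C/C(=O)Nc3ccccc3OCCCC(=O)O)ccc21` changes the same position: 1-phenylpropyl in place of 4-methylbenzyl on an aromatic nitrogen. Among the compounds with values here, two measured steps bear on this change. The step of a 9.5-fold higher number from compound 2 to compound 3 (0.98 log units; beyond the scatter) and the step of a 13-fold lower number from compound 1 to compound 2 (1.11 log units; beyond the scatter) both pair a 1-ethylbutyl group on this nitrogen with a clearly lower number than a 4-methylbenzyl or 3-methylbut-2-en-1-yl group. Compound 4 resembles compound 2 in the shape of its attachment, so a lowering is expected, about a 2.9-fold lower number from compound 3 to compound 4 (0.47 log units; beyond the scatter). Compound 4 is therefore estimated at 30 nM, within a range from 10 nM to 90 nM.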

Compound 4, half-maximal inhibitory concentration: 19 nM
For compound 4 the middle estimate is 1.6-fold (0.20 log units) above the measured one; the measured number falls inside the stated range.
By their numbers in this assay, from the lowest: compound 2; then compound 4; then compounds 3 and 1 (each within the scatter of the next).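

With 1-phenylpropyl on the aromatic nitrogen, the six-membered aromatic ring stays, yet a 4.6-fold lower number from compound 3 to compound 4 (0.67 log units; beyond the scatter) and a 6.3-fold lower number from compound 1 to compound 4 (0.80 log units; beyond the scatter) show that a ring in this group does not by itself keep the number high. Phenyl in place of propyl still brings a 2.0-fold higher number from compound 2 to compound 4 (0.31 log units; beyond the scatter) and leaves compound 2 with the lowest number of the four. Nothing shown here explains these differences. Still open, as far as these compounds go, is how a 1-phenylethyl group, with its shorter chain, would compare, or a 1-phenylpropyl group carrying a fluorine or an amine on its ring.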